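An open step from compound 3 to compound 4

The source may hold more compounds than are shown below. What is called first, only, known or untested is meant among the compounds shown, and "the series" means these compounds.

In a functional assay on KB cells (Homo sapiens) for inhibition, read by sulforhodamine B assay, with a stated time of 72 h (on this read-out higher numbers stand for weaker inhibition of growth and lower numbers for stronger inhibition of growth), compound 3 (`CCOC(=O)/C=C/c1ccncc1-c1ccc2ccccc2c1`) gives > 10000 nM as a limit and not a number. In this assay compound 1 (`CN1CCN(C(=O)/C=C/c2ccncc2-c2ccc3ccccc3c2)CC1`) also stops at a limit with > 10000 nM as its entry. In this assay compound 2 (`CCOC(=O)/C=C/c1ccncc1-c1ccc2[nH]ccc2c1`) likewise shows only a limit with > 10000 nM as its entry. Among the measured compounds shown here, the series so far comes down to the limit of > 10000 nM in this assay, at which 3 of the 3 values shown sit, and none of its members has a number.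

The change to compound 4 (`CNC(=O)CCc1ccncc1-c1ccc2ccccc2c1`) is 2-(methylcarbamoyl)ethyl in place of 2-(ethoxycarbonyl)ethenyl on an aromatic carbon and puts 2-(methylcarbamoyl)ethyl in place of 2-(ethoxycarbonyl)ethenyl. For the measured compounds named here, the only measured step nearby is a step that the two limits leave unreadable from compound 1 to compound 3 and it offers no size to carry over. The expectation therefore rests on compound 3 and its limit > 10000 nM alone. The expected size is a step that the limit leaves unreadable from compound 3 to compound 4 and no step beyond the scatter is expected in this assay in either direction. Compound 4 is estimated at 15000 nM with an expected range from 5000 nM to 40000 nM and may well end up only as a limit.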

Compound 4, concentration for 50% growth inhibition: > 10000 nM
Compound 4: a limit, no number; the forecaster's own chance of this, stated with the estimate: 85%; the middle value does not contradict the limit.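

In this assay compound 4 gives > 10000 nM, a limit and not a number; compound 3 also stops at a limit, so no step can be read between compound 3 and compound 4. The compounds shown leave open how strongly any of them inhibits growth, and whether any change to the shared core alters that, as the whole series rests at one entry: the limit of > 10000 nM in this assay, at which 4 of the 4 values shown sit.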